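The source may report more compounds than this note shows. Statements on the series, on what has been measured and on what is new or still open speak of the compounds shown alone.

Compound 1 `CCc1nc2c(-c3ccc(Cl)cc3Cl)ccnc2n1C(CCOC)C1CC1` is one of two compounds with a measurement in an assay for binding affinity to Corticotropin releasing factor receptor (Rattus norvegicus); on this read-out higher numbers stand for weaker inhibition and lower numbers for stronger inhibition. In this assay compound 1 gives 1.5 nM, which is the higher of the two numbers, yet the gap to compound 2 `CCCC(C)n1c(CC)nc2c(-c3ccc(SC)cc3C(F)(F)F)ccnc21`, which in this assay gives 1.4 nM, lies within the usual scatter of repeated measurements, so the two compounds cannot be told apart on these data. Compound 3 `CCc1nc2c(-c3ccc(Cl)cc3Cl)ccnc2n1C(C)CC` has not yet been measured. It differs from compound 1 in one place: sec-butyl in place of 1-cyclopropyl-3-methoxypropyl on an aromatic nitrogen. The chain that leaves is long and carries a ring and an ether oxygen; the chain that enters is short and plain. Among the measured compounds shown here, there is no measured pair in this set that isolates such a change, so the size of the step is open. The step of a 2.0-fold higher number from compound 1 to compound 3 (0.30 log units; within the scatter) is expected to be small, if any, because compound 2, which carries a different branched chain on the aromatic nitrogen, gives 1.4 nM. Compound 3 is therefore expected to give about 3 nM, with a likely range from 1 nM to 10 nM.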

Compound 3, inhibition constant: 1.3 nM
The estimate for compound 3 lay 2.3-fold (0.36 log units) above the measured number, within the range that was stated.
By their numbers in this assay, from the lowest: compounds 3, 2 and 1 (each within the scatter of the next).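

In this assay, replacing 1-cyclopropyl-3-methoxypropyl with sec-butyl on the aromatic nitrogen gives a 1.2-fold lower number from compound 1 to compound 3 (0.06 log units; within the scatter) and so leaves compound 1 and compound 3 indistinguishable. Among the compounds shown here, this is the first direct comparison at this position with everything else held the same, and it shows that on this core the binding number stays within the scatter when the cyclopropyl ring, the ether oxygen and much of the chain are all absent. Nothing available here explains why two such different chains give such similar numbers.

Because the ring, the ether oxygen and the chain length all differ at once, this single pair cannot show what each contributes, and a plain methyl group, a longer unbranched chain or a chain ending in an amine could give quite different numbers at this position. From the compounds shown here alone, it also remains open whether the same swap would behave alike with the other aromatic ring, the one bearing methylthio and trifluoromethyl groups in compound 2.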